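A few compounds are considered here, and "the series" means these few. Any claim that something is new, unique, unknown or untested is made for them only; others in the source may bear on it.

Of the compounds shown here, two have been measured so far in an assay on HEK293 cells for positive allosteric modulation of metabotropic glutamate receptor 3 (Rattus norvegicus), read by thallium flux, with a stated time of 2.5 min; on this read-out lower numbers stand for smaller maximal responses and higher numbers for larger maximal responses. Compound 1, `Cc1c(OCCCCOc2ccc(F)c(C(=O)O)c2)ccc(C(=O)CC(C)(C)C)c1O`, gives 102% in this assay. Compound 2, `Cc1c(OCCCCOc2ccc(C(=O)O)cc2Cl)ccc(C(=O)CC(C)C)c1O`, gives 62.9% in this assay, which is the lowest of the two numbers, and the gap up to compound 1 lies beyond the usual scatter. Among the measured compounds shown here, the two compounds differ in more than one place, so no single step between them can be read off.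

Compound 3, `Cc1c(OCCCCOc2ccc(F)c(C(=O)O)c2)ccc(C(=O)CC(C)C)c1O`, has not yet been measured. It differs from compound 2 in one place: 3-carboxy-4-fluorophenyl in place of 4-carboxy-2-chlorophenyl on an oxygen on a saturated carbon. The group that enters is the same 3-carboxy-4-fluorophenyl that compound 1 carries, and compound 1 sits well above compound 2. On that ground the step from compound 2 to compound 3 is expected to be upward, roughly a number 27.1 percentage points higher from compound 2 to compound 3 (beyond the scatter), beyond the scatter. The expected value for compound 3 in this assay is about 90%, with a likely range from 62% to 115%.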

Compound 3, largest response reached (reported as percent of maximum), in percent of the reference or control that the assay uses: 81.7%
Compound 3: the middle estimate sits 8.3 percentage points above what was measured; the range from low to high includes it.
By their numbers in this assay, from the lowest: compound 2; then compound 3; then compound 1.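

In this assay, 3-carboxy-4-fluorophenyl in place of 4-carboxy-2-chlorophenyl on an oxygen on a saturated carbon gives a number 18.8 percentage points higher from compound 2 to compound 3 (beyond the scatter), so this group alone moves the maximal response. A second place matters too: hydrogen in place of methyl on a saturated chain carbon bound to three saturated chain carbons gives a number 20.3 percentage points lower from compound 1 to compound 3 (beyond the scatter). Compound 3 thus splits the gap in compound 1 and compound 2, which differ in more than one place, into two single changes that each count.

Nothing measured here gives a reason for either step. Going by these compounds, the swap of the aromatic group changes the halogen and the carboxylic acid's place on the ring together, so which of the two carries the step stays open, as does the effect of an amide or a methyl ester in place of the carboxylic acid.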